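The compounds below may be only part of what the source reports. "The series", "measured", "known", "first", "only" and "open" are said of these compounds alone.

In a functional assay on MCF7 cells (Homo sapiens) for antiproliferative activity, read by MTT assay, with a stated time of 72 h (on this read-out higher numbers stand for weaker inhibition and lower numbers for stronger inhibition), the measured compounds are:
- Compound 1 `O=S(=O)(Oc1ccc(Br)cc1)C1CC2OC1C(c1ccc(/C=C/c3cc(O)cc(O)c3)cc1)=C2c1ccc(O)cc1` gives 16900 nM
- Compound 2 `O=S(=O)(Oc1ccccc1Cl)C1CC2OC1C(c1ccc(/C=C/c3cc(O)cc(O)c3)cc1)=C2c1ccc(O)cc1` gives 40400 nM

Compound 2 holds the higher of these two numbers. Compound 3 `Cc1ccccc1OS(=O)(=O)C1CC2OC1C(c1ccc(/C=C/c3cc(O)cc(O)c3)cc1)=C2c1ccc(O)cc1` carries methyl in place of chloro on an aromatic carbon, ortho to a large group (methyl in place of chloro on an aromatic carbon). Going by the values given here, the only measured step, a 2.4-fold higher number from compound 1 to compound 2 (0.38 log units; beyond the scatter), is modest and replaces 4-bromophenyl with 2-chlorophenyl, so it bears only loosely on this change. Among the compounds with values here, no measured pair exchanges these two groups, and no step beyond the scatter is expected in this assay. The estimated step is a 1.1-fold lower number from compound 2 to compound 3 (0.05 log units; within the scatter). For compound 3 the expected value is 36000 nM, with an expected range from 16000 nM to 80000 nM.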

Compound 3, half-maximal inhibitory concentration: 55800 nM
Compound 3: the middle estimate sits 1.6-fold (0.19 log units) below what was measured; low and high end bracket the measured number.
By their numbers in this assay, from the lowest: compound 1; then compounds 2 and 3 (each within the scatter of the next).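

In this assay, methyl and chloro on this aromatic carbon, ortho to a large group, cannot be told apart, with a 1.4-fold higher number from compound 2 to compound 3 (0.14 log units; within the scatter). The 2-methylphenyl group also stands apart from 4-bromophenyl, with a 3.3-fold higher number from compound 1 to compound 3 (0.52 log units; beyond the scatter), so both groups at this place give modest steps in the same direction from compound 1. Nothing measured here accounts for this result. As far as these compounds go, it remains open whether the gap to compound 1 follows the group or its place on the ring, and how an amine or a carboxylic acid on this carbon would read.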